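The source may report more compounds than this note shows. Statements on the series, on what has been measured and on what is new or still open speak of the compounds shown alone.

In an assay on isolated protein for inhibition of cytosolic endo-beta-N-acetylglucosaminidase (Homo sapiens), tested at 1000 uM (on this read-out lower numbers stand for less inhibition and higher numbers for more inhibition at the one concentration tested (going by the name of the read-out)), compound 2 `O=C(O)[C@H]1NC[C@H](O)[C@@H](O)[C@H]1O` gives 2.6% and stands lowest of the three numbers shown. Compound 1 `O=C(O)[C@@H]1NCC=C[C@H]1O` gives 14% in this assay and compound 3 `O=C(O)[C@H]1NCC=C[C@@H]1O` gives 60% there. Compound 4 `O=C(O)[C@@H]1NC[C@H](O)[C@H](O)[C@H]1O` is the unmeasured partner of compound 2, and the change is the two compounds have the same atoms and bonds and differ only in configuration as drawn: 2 of 4 stereo elements differ; a stereocentre at a saturated ring carbon is drawn S in compound 2 and R in compound 4; a stereocentre at a saturated ring carbon is drawn R in compound 2 and S in compound 4 as drawn. For the measured compounds named here, the only measured step that turns on configuration alone is a number 46 percentage points higher from compound 1 to compound 3 (beyond the scatter) in this assay, and because the fact that compounds 1 and 3 differ only in the configuration as drawn holds it shows that arrangement in space alone can move the read-out by a large amount. That step was a full mirror image, while compound 4 inverts only some of the centres of compound 2, so the size need not carry over. An upward shift is nonetheless expected, given that compound 2 sits at 2.6% already. The estimate for compound 4 is 12% with a range from 1% to 45% in this assay, an expected step of a number 9.4 percentage points higher from compound 2 to compound 4 (within the scatter) overall.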

Compound 4, a percentage reported as inhibition, at one concentration (the size of the read-out at that concentration, not a potency): 39%
Beside the measured number, compound 4's estimate is 27 percentage points below it; the range from low to high includes it.
By their numbers in this assay, from the lowest: compound 2; then compound 1; then compound 4; then compound 3.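

Inverting only 2 of the 4 stereo elements gives a number 36.4 percentage points higher from compound 2 to compound 4 (beyond the scatter) in this assay, so a large change in this read-out does not need a full mirror image like the one relating compound 1 and compound 3. Configuration at these two ring carbons alone can therefore turn near-absent inhibition into clear inhibition at the one concentration tested: the fact that compounds 2 and 4 differ only in the configuration as drawn. As far as these compounds go, whether inverting just one of these two centres would have the same effect remains open. So does whether a methyl ester in place of the carboxylic acid would preserve any inhibition.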